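Stereochemical Inversion at the Cyclobutane Core and Clearance

A few compounds are considered here, and "the series" means these few. Any claim that something is new, unique, unknown or untested is made for them only; others in the source may bear on it.

Measured compounds:
- compound 1, `C[C@]1(O)C[C@](c2cccc(OC(F)(F)F)c2)([C@H](O)c2ccccn2)C1`: 117 mL/min/kg
- compound 2, `C[C@]1(O)C[C@](c2cccc(C(F)(F)F)c2)([C@H](O)c2ccccn2)C1`: 33.3 mL/min/kg
- compound 3, `O[C@H](c1ccccn1)[C@]1(c2cccc(C(F)(F)F)c2)C[C@H](O)C1`: 133 mL/min/kg

In an ADME assay on liver for metabolic stability, with Liver microsome (Homo sapiens) as the target, read by LC-MS, using microsomes, with a stated time of 5 h (a lower number here means slower removal, a higher number faster removal of the compound), compound 2 stands lowest of the three, with compound 1 nearest and compound 3 furthest. The two measured steps both change substituents: a 3.5-fold lower number from compound 1 to compound 2 (0.55 log units; beyond the scatter), and a 4.0-fold higher number from compound 2 to compound 3 (0.60 log units; beyond the scatter). Neither step touches configuration, so neither bears directly on the move to compound 4, `C[C@]1(O)C[C@@](c2cccc(C(F)(F)F)c2)([C@H](O)c2ccccn2)C1`. Compared with compound 2, (the two compounds have the same atoms and bonds and differ only in configuration as drawn: 2 of 3 stereo elements differ; a stereocentre at a saturated ring carbon is drawn S in compound 2 and R in compound 4; a stereocentre at a saturated ring carbon is drawn r in compound 2 and s in compound 4). Among the compounds with values here, there is no measured stereochemical pair in this set, so the direction of the step cannot be read from the data; the substituent steps only show how large a change in this assay can be for a single alteration. Compound 4 is therefore expected to give 45 mL/min/kg in this assay, within a range of 18 mL/min/kg to 115 mL/min/kg. The step that this estimate implies, a 1.4-fold higher number from compound 2 to compound 4 (0.13 log units; within the scatter), is expected to be modest in size, with the wide range reflecting that a configurational change could move the number either way.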

Compound 4, clearance: 150 mL/min/kg
Estimate against measurement, compound 4: 3.3-fold (0.52 log units) below; the whole stated range lies below it.
By their numbers in this assay, from the lowest: compound 2; then compounds 1, 3 and 4 (each within the scatter of the next).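

In this assay, a change of configuration alone moves the number as far as the substituent changes did, with a 4.5-fold higher number from compound 2 to compound 4 (0.65 log units; beyond the scatter), so the earlier steps, which left configuration as drawn, could not have shown that the saturated ring carbons matter in this way. The low number of compound 2 therefore does not follow from its atoms and bonds alone: compound 4 carries the same trifluoromethyl, methyl and hydroxyl groups and still gives 150 mL/min/kg. The step can be assigned to configuration and to nothing else, because no other feature separates the pair: the fact that compounds 2 and 4 differ only in the configuration as drawn

Two stereo elements differ together in this pair, so the compounds shown do not tell which of them carries the step, nor whether the trifluoromethoxy compound or the compound with hydrogen in place of methyl would respond in the same way to the same inversion. They also leave open whether an amine or a methoxy group in place of the hydroxyl on the saturated ring carbon would keep the number of compound 2 in either configuration.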